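A few compounds are considered here, and "the series" means these few. Any claim that something is new, unique, unknown or untested is made for them only; others in the source may bear on it.

Compound 1, whose structure is `CC(C)c1cc2c(cc1NS(=O)(=O)c1ccc(-c3ccc(Cl)cc3)cc1)CCN(C)CC2`, was tested in an assay on isolated protein for displacement of a labelled ligand from 5-hydroxytryptamine receptor 6 (Homo sapiens), read by radioligand binding (on this read-out lower numbers stand for stronger inhibition and higher numbers for weaker inhibition), where compound 1 gives 12.6 nM. Two other compounds have been measured in this assay. Compound 2, with the structure `CCCCc1ccc(S(=O)(=O)Nc2ccc3c(c2)CCNCC3)cc1`, gives 2 nM; compound 3, with the structure `CCCCc1ccc(S(=O)(=O)Nc2ccc3c(c2)CNC3)cc1`, gives 50.1 nM. Among these three numbers compound 1 stands second highest: the nearest is compound 3, whose number is higher by a margin beyond the usual scatter, and the furthest is compound 2, whose number is lower, again by a margin beyond the scatter. Among the measured compounds shown here, none of these three compounds differs from another in just one place, so no single-change step is available for comparison.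

Compound 4, whose structure is `COc1cc2c(cc1NS(=O)(=O)c1ccc(-c3ccc(Cl)cc3)cc1)CCN(C)CC2`, has not yet been measured in this assay. It differs from compound 1 in one place: methoxy in place of isopropyl on an aromatic carbon. For the measured compounds named here, no measured pair in this set isolates such a swap, so there is nothing to calibrate its effect. On that basis the expectation is for no step beyond the scatter, and compound 4 is estimated at 10 nM, with a range from 3 nM to 40 nM, which would mean an expected step of a 1.3-fold lower number from compound 1 to compound 4 (0.10 log units; within the scatter).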

Compound 4, inhibition constant: 10 nM
Beside the measured number, compound 4's estimate shows no gap at the digits printed, and the stated range covers the measured number.
By their numbers in this assay, from the lowest: compound 2; then compounds 4 and 1 (each within the scatter of the next); then compound 3.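

Compounds 1, 2 and 3 differ from one another in more than one place, so they could not show what a single change does; this pair gives the first such reading. In this assay, the change of methoxy in place of isopropyl on an aromatic carbon, ortho to a large group, gives a 1.3-fold lower number from compound 1 to compound 4 (0.10 log units; within the scatter), so with the rest of the molecule held constant, this swap produces no measurable shift, even though the entering group brings an oxygen and a hydrogen-bond acceptor that isopropyl lacks. No measurement is available that would explain this result.

Going by these compounds, a single swap between two groups of similar size says little about how much freedom this position allows, so it remains open whether a bare hydrogen, a chlorine atom, a primary amine or a carboxylic acid in the same place would also leave the number unmoved. On these data alone, it also remains open whether methoxy and isopropyl would match in the same way on a core with a different group on the far end of the sulfonamide.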